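Pyrrolidine carbinol variation on a chemokine receptor antagonist series

This account rests on a few compounds, and the source may have more. Where it says the series, first, only, none or still open, it means among the compounds named here.

Three compounds share a dichlorophenyl ethyl side chain on a bicyclic core. Compound 1 `Cc1nn([C@H](C)c2ccc(Cl)cc2Cl)c2nc(N3CC[C@H](N4CCC[C@H]4C(N)=O)[C@H](C)C3)cnc12` carries a carboxamide on its pyrrolidine; in an assay on CCRF-CEM cells for antagonist activity at C-C chemokine receptor type 4 (Homo sapiens), read by CellTiter-Glo, with stated times of 30 min and 60 min, in the presence of a further agent that is not named here (a lower number here means a stronger inhibitor, a higher number a weaker inhibitor), compound 1 gives "not determined" (no result reported), so no number stands for it. Compound 2 `Cc1nn([C@H](C)c2ccc(Cl)cc2Cl)c2nc(N3CC[C@H](N4CCCCC4)[C@H](C)C3)cnc12` gives 361 nM in this assay. Compound 3 `C[C@@H]1CC(c2cnc3c(C#N)nn([C@H](C)c4ccc(Cl)cc4Cl)c3n2)=CC[C@@H]1N1CCC[C@H]1CO`, which bears a nitrile on the core and a hydroxymethyl pyrrolidine on a cyclohexene, gives 70 nM in this assay and holds the lowest of the two numbers; the gap to compound 2 lies beyond the scatter.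

Compound 4 `C[C@@H]1CC(c2cnc3c(C#N)nn([C@H](C)c4ccc(Cl)cc4Cl)c3n2)=CC[C@@H]1N1CCC[C@H]1C(C)(C)O` differs from compound 3 in one place: 1-hydroxy-1-methylethyl in place of hydroxymethyl on a saturated ring carbon. For the measured compounds named here, no measured pair shows this change, so no direct precedent sets its size. Going by the values given here, the hydroxyl is kept, only two methyl groups enter on the same carbon, and a step of no more than the scatter, in either direction, is expected. Compound 4 is therefore estimated at 55 nM in this assay, within 20 nM to 150 nM. The expected step of a 1.3-fold lower number from compound 3 to compound 4 (0.10 log units; within the scatter) is small.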

Compound 4, half-maximal inhibitory concentration: 1200 nM
Compound 4: the middle estimate sits 22-fold (1.34 log units) below what was measured; the whole stated range lies below it.
By their numbers in this assay, from the lowest: compound 3; then compound 2; then compound 4.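

For the compounds shown here, the step of a 17-fold higher number from compound 3 to compound 4 (1.23 log units; beyond the scatter) gives the first reading of this position, a saturated ring carbon next to the ring nitrogen, in this assay and shows that the number there is highly sensitive to this change. The hydroxyl is present on both sides of the step and the hydrogen-bond donor and acceptor counts are the same, so keeping these features did not preserve the number when 1-hydroxy-1-methylethyl, with 4 heavy atoms, replaced hydroxymethyl, with 2. Nothing in the available data accounts for the size of this step.

The compounds shown leave open whether 1-hydroxyethyl, with a single methyl on the carbinol carbon, would read closer to compound 3 or to compound 4. On these data alone, how aminomethyl or methoxymethyl would read on this carbon also remains open.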